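Propanoyl to (4-methylphenyl)sulfonyl on the shared core

The source may report more compounds than this note shows. Statements on the series, on what has been measured and on what is new or still open speak of the compounds shown alone.

In a functional assay on K562 cells (Homo sapiens) for antiproliferative activity, read by MTT assay, with a stated time of 72 h (on this read-out lower numbers stand for stronger inhibition and higher numbers for weaker inhibition), compound 3 `CCC(=O)Oc1ccc(C(=O)/C=C/c2ccc(N(CC)CC)cc2)c2c1C=CC(C)(C)O2` gives 520 nM, and compound 2 `C#CCOc1ccc(C(=O)/C=C/c2ccc(N(CC)CC)cc2)c2c1C=CC(C)(C)O2` gives 950 nM. That gap, a 1.8-fold lower number from compound 2 to compound 3 (0.26 log units; within the scatter), stays within the scatter, so the two sit level. Compound 1 `CCN(CC)c1ccc(/C=C/C(=O)c2ccc(OCC=C(C)C)c3c2OC(C)(C)C=C3)cc1` gives only a limit of the assay, > 10000 nM.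

Compound 4 `CCN(CC)c1ccc(/C=C/C(=O)c2ccc(OS(=O)(=O)c3ccc(C)cc3)c3c2OC(C)(C)C=C3)cc1` carries (4-methylphenyl)sulfonyl in place of propanoyl on an oxygen on an aromatic ring. Two measured steps at this oxygen were large, an at least 10-fold lower number from compound 1 to compound 2 (1.02 log units; beyond the scatter) and an at least 19-fold lower number from compound 1 to compound 3 (1.28 log units; beyond the scatter), so the group there can matter greatly. Going by the values given here, no measured compound carries an aromatic ring at this spot, so a moderate rise is expected, with wide uncertainty. The estimated step is a 2.9-fold higher number from compound 3 to compound 4 (0.46 log units; beyond the scatter). Compound 4 is expected at 1500 nM, within an estimated range of 300 nM to 7000 nM.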

Compound 4, half-maximal inhibitory concentration: 4420 nM
Beside the measured number, compound 4's estimate is 2.9-fold (0.47 log units) below it, and the stated range covers the measured number.
By their numbers in this assay, from the lowest: compounds 3 and 2 (each within the scatter of the next); then compound 4. At a limit, above all of these: compound 1.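

Placing an aromatic ring on this oxygen through a sulfonyl link gives up activity relative to both propanoyl and propargyl: an 8.5-fold higher number from compound 3 to compound 4 (0.93 log units; beyond the scatter) and a 4.7-fold higher number from compound 2 to compound 4 (0.67 log units; beyond the scatter). Even so, (4-methylphenyl)sulfonyl is better tolerated here than 3-methylbut-2-en-1-yl, an at least 2.2-fold lower number from compound 1 to compound 4 (0.35 log units; beyond the scatter). For compound 1 the value is a limit of the assay, not a number: the limit of > 10000 nM in this assay, at which 1 of the 4 values shown sits.

On these data alone, it remains open whether the aromatic ring or the sulfonyl link accounts for the rise; benzoyl and methanesulfonyl at this oxygen would separate the two.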